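Swapping a Triazole Diol for a Propylpiperazine Chain

The source may hold more compounds than are shown below. What is called first, only, known or untested is meant among the compounds shown, and "the series" means these compounds.

Compound 1, `O=C1c2c[n+]([O-])c3ccccc3c2C(=O)c2c1c1ccccc1n2Cc1cn(C[C@@H](O)CO)nn1`, has been tested in a functional assay on SH-SY5Y cells (Homo sapiens) for cytotoxicity, read by MTT assay, with a stated time of 72 h; on this read-out lower numbers stand for stronger inhibition and higher numbers for weaker inhibition. In this assay compound 1 gives only a limit, > 500 nM, so its place among the measured compounds is known only as a bound. Compound 2, `CC1(C)O[C@@H](CO)[C@H](Cn2cc(Cn3c4c(c5ccccc53)C(=O)c3c[n+]([O-])c5ccccc5c3C4=O)nn2)O1`, likewise gives only a limit in this assay, > 1000 nM. Among the compounds with values here, compound 3, `CC1(C)OCC(Cn2cc(Cn3c4c(c5ccccc53)C(=O)c3c[n+]([O-])c5ccccc5c3C4=O)nn2)O1`, is the one measured compound with a number, giving 230 nM in this assay. The two readable steps, an at least 2.1-fold lower number from compound 1 to compound 3 (0.33 log units; beyond the scatter) and an at least 4.3-fold lower number from compound 2 to compound 3 (0.63 log units; beyond the scatter), both move toward lower numbers when the 2,2-dimethyl-1,3-dioxolan-4-yl group enters, while the step that the two limits leave unreadable from compound 1 to compound 2 cannot be sized because of the limit of > 1000 nM in this assay, at which 1 of the 3 values shown sits, and (the limit of > 500 nM in this assay, at which 1 of the 3 values shown sits).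

Compound 4, `CCCN1CCN(CCCCn2c3c(c4ccccc42)C(=O)c2c[n+]([O-])c4ccccc4c2C3=O)CC1`, is not yet measured. It differs from compound 1 by 3-(4-propylpiperazin-1-yl)propyl in place of 1-(2,3-dihydroxypropyl)-1H-1,2,3-triazol-4-yl on a saturated chain carbon bound to an aromatic nitrogen. Within the data shown here, none of the measured steps concerns this group, so they bear on it only indirectly; they show that the shared core can reach the number of compound 3 when the side chain changes. Compound 4 is therefore expected to give 300 nM in this assay, within 80 nM to 2000 nM. That estimate amounts to an at least 1.6-fold lower number from compound 1 to compound 4 (0.22 log units; that floor lies within the scatter).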

Compound 4, half-maximal inhibitory concentration: 3970 nM
Compound 4: middle estimate off by 13-fold (1.12 log units), on the low side; measured number above the stated range.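

No new step can be read: compound 4 now has a number, but the step to it from compound 1 stays unreadable because compound 1 carries only a limit: the limit of > 500 nM in this assay, at which 1 of the 4 values shown sits.

The compounds shown leave open how far 3-(4-propylpiperazin-1-yl)propyl truly differs from 1-(2,3-dihydroxypropyl)-1H-1,2,3-triazol-4-yl on the shared core.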